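The source may hold more compounds than are shown below. What is called first, only, known or untested is meant among the compounds shown, and "the series" means these compounds.

In a functional assay on microsomes from liver (Rattus norvegicus, strain Wistar) for inhibition, with a stated time of 15 min (a lower number here means a stronger inhibitor, a higher number a weaker inhibitor), the three measured compounds gave:
Compound 1 `COc1ccc(NC(=O)N2N=C(c3cc4ccccc4o3)CC2c2ccc(O)c(OC)c2)cc1`: 29000000 nM
Compound 2 `COc1cc(C2CC(c3cc4ccccc4o3)=NN2C(=O)Nc2ccc([N+](=O)[O-])cc2)ccc1O`: 113000000 nM
Compound 3 `COc1cc(C2CC(c3cc4ccccc4o3)=NN2C(=O)Nc2ccc(C)cc2)ccc1O`: 44000000 nM

Compound 2 stands highest of the three, so it is the weakest inhibitor here: a 3.9-fold higher number from compound 1 to compound 2 (0.59 log units; beyond the scatter) and a 2.6-fold lower number from compound 2 to compound 3 (0.41 log units; beyond the scatter), both beyond the scatter. The unmeasured compound 4 `COc1cc(C2CC(c3cc4ccccc4o3)=NN2C(=O)Cl)ccc1O` differs from compound 2 by chloro in place of (4-nitrophenyl)amino on a carbonyl carbon. Every measured step swapped one group on an aromatic carbon of the outer ring (a 1.5-fold higher number from compound 1 to compound 3 (0.18 log units; within the scatter) among them), whereas this change removes that whole ring and its nitrogen from the carbonyl carbon, so none of the steps bears on it directly. No direction can be read from the data, and the expected step of a 2.8-fold lower number from compound 2 to compound 4 (0.45 log units; beyond the scatter) is therefore modest, with a wide range. Compound 4 is estimated at 40000000 nM, between 8000000 nM and 200000000 nM.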

Compound 4, half-maximal inhibitory concentration: 147000000 nM
Compound 4: the middle estimate sits 3.7-fold (0.57 log units) below what was measured, and the stated range covers the measured number.
By their numbers in this assay, from the lowest: compounds 1 and 3 (each within the scatter of the next); then compounds 2 and 4 (each within the scatter of the next).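

Chloro in place of (4-nitrophenyl)amino on the carbonyl carbon leaves the number within the scatter (a 1.3-fold higher number from compound 2 to compound 4 (0.11 log units; within the scatter)), so at this level of inhibition, losing that whole ring and its nitrogen changes nothing that can be read. The same kind of swap does count from the other two compounds (a 3.3-fold higher number from compound 3 to compound 4 (0.52 log units; beyond the scatter); a 5.1-fold higher number from compound 1 to compound 4 (0.70 log units; beyond the scatter)), so (4-methylphenyl)amino and (4-methoxyphenyl)amino give lower numbers than chloro, while (4-nitrophenyl)amino does not. Nothing measured here explains this difference. Still open, going by these compounds, is whether a simple amine or a hydroxyl on the same carbonyl carbon would sit with compound 4 or with compound 1.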